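This account rests on a few compounds, and the source may have more. Where it says the series, first, only, none or still open, it means among the compounds named here.

In a functional assay for inhibition, with Rattus norvegicus as the target (a higher number here means a weaker inhibitor, a lower number a stronger inhibitor), compound 2 `CCCCCCC/N=c1\c(O)c(O)\c1=N/c1ccc(C#N)cc1` gives > 30000 nM as a limit of the assay and not a number. Compound 1 `CC(/N=c1\c(O)c(O)\c1=N/c1ccc(C#N)cc1)C(C)(C)C` gives 520 nM as a measured reading. The next analogue, compound 3 `C[C@@H](/N=c1\c(O)c(O)\c1=N/c1ccc(C#N)cc1)c1ccccc1`, carries 1-phenylethyl in place of heptyl on a double-bonded nitrogen. Going by the values given here, only one measured step bears on this change (an at least 57-fold higher number from compound 1 to compound 2 (1.76 log units; beyond the scatter)), and it is large and beyond the scatter, with heptyl entering in place of 1,2,2-trimethylpropyl on the same nitrogen. Compound 3 also loses heptyl, so a large move to a lower number is expected in this assay on that single step. The 1-phenylethyl group brings one six-membered aromatic ring that compound 1 lacks, so a full return to compound 1 is not assumed. The expected change is an at least 20-fold lower number from compound 2 to compound 3 (1.30 log units; beyond the scatter) in size. For compound 3 the estimated value is 1500 nM (250 nM to 9000 nM).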

Compound 3, half-maximal inhibitory concentration: 56 nM
Compound 3: middle estimate off by 27-fold (1.43 log units), on the high side; the measured number lies below the stated range.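

In this assay, the double-bonded nitrogen accepts a six-membered aromatic ring of carbon only, and 1-phenylethyl goes beyond the best reading among the ring-free groups, with a 9.3-fold lower number from compound 1 to compound 3 (0.97 log units; beyond the scatter). Against the straight chain, the same position gives an at least 530-fold lower number from compound 2 to compound 3 (2.72 log units; beyond the scatter), so the two ring-free groups and 1-phenylethyl span a wide range at this one place. Compound 2 stands at a limit of the assay and not at a number: the limit of > 30000 nM in this assay, at which 1 of the 3 values shown sits.

Only one defined stereocentre of 1-phenylethyl is shown, so the reading of its mirror-image form and of benzyl, which lacks the methyl, remains open. Also open, on these data alone, is whether 1-cyclohexylethyl, with a saturated ring in place of the aromatic one, would keep the lower number of compound 3.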